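Swapping Chloro for Bromo in a Small Set of Growth Inhibitors

The source may report more compounds than this note shows. Statements on the series, on what has been measured and on what is new or still open speak of the compounds shown alone.

Of the compounds shown here, three have been measured in a functional assay on DU-145 cells (Homo sapiens) for inhibition, read by trypan blue exclusion, with a stated time of 96 h; a lower number here means a stronger inhibitor of growth, a higher number a weaker inhibitor of growth. Compound 1 `COc1ccc(/C=C(\C(=O)c2ccc(Br)cc2)S(=O)(=O)c2ccc(Br)cc2)cc1` gives 25000 nM. Compound 2 `COc1ccc(/C=C(\C(=O)c2ccc(Cl)cc2)S(=O)(=O)c2ccc(Br)cc2)cc1`, in this assay, gives 10000 nM. Compound 3 `O=C(/C(=C\c1ccc(Cl)c([N+](=O)[O-])c1)Sc1ccc(Br)cc1)c1ccc(Br)cc1` gives 10000 nM, level with compound 2 at the digits shown, and these two together hold the lowest numbers of the three. The difference between the core of compound 3 and the core of compound 2 is not broken down here.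

One single-point change is seen within the measured set: bromo in place of chloro on an aromatic carbon, and in this assay it made a 2.5-fold higher number from compound 2 to compound 1 (0.40 log units; beyond the scatter).

Compound 4 `O=C(/C(=C\c1ccc(Br)c([N+](=O)[O-])c1)Sc1ccc(Br)cc1)c1ccc(Br)cc1` has not yet been measured. It differs from compound 3 by bromo in place of chloro on an aromatic carbon. Going by the values given here, this is the same kind of change as the one from compound 2 to compound 1, but not the same: in compound 4 the aromatic carbon that takes the bromo is ortho to a nitro group, while around the earlier change no such group stands. Because the earlier change is recorded as a 2.5-fold higher number from compound 2 to compound 1 (0.40 log units; beyond the scatter), a step of similar size and direction is expected here, though with wider uncertainty: the surroundings differ, and the expectation rests on a single measured pair. The step from compound 3 to compound 4 is estimated to be a 2.0-fold higher number from compound 3 to compound 4 (0.30 log units; within the scatter). Compound 4 is therefore expected to give about 20000 nM in this assay, with a range from 7000 nM to 50000 nM.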

Compound 4, concentration for 50% growth inhibition: 1000 nM
Estimate against measurement, compound 4: 20-fold (1.30 log units) above; the whole stated range lies above it.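

In this assay, putting bromo in place of chloro on an aromatic carbon gave a 10-fold lower number from compound 3 to compound 4 (1.00 log units; beyond the scatter), a step in the opposite direction to the one seen earlier. In this series, then, the change does not carry from one core to another with a fixed size or even a fixed direction: the same change on two cores in this assay, a 2.5-fold higher number (0.40 log units; beyond the scatter) from compound 2 to compound 1 and a 10-fold lower number (1.00 log units; beyond the scatter) from compound 3 to compound 4, 25-fold (1.40 log units) apart, beyond the scatter of two such steps. What the two pairs do not show is which difference between the cores lies behind the split, for although the carbon taking the bromo in compound 4 is ortho to a nitro group and no such group stands around the earlier change, the cores differ elsewhere as well, and two pairs cannot tell how the swap would behave on a third core.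

The compounds shown leave open how the same swap would behave with an amine in place of the nitro group, and whether fluoro on that aromatic carbon would follow the bromo or the chloro. They also leave open which part of the difference between the core of compound 2 and the core of compound 3 decides the direction of the step, as no pair shown isolates any one part of it.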